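The source may report more compounds than this note shows. Statements on the series, on what has been measured and on what is new or still open speak of the compounds shown alone.

Measured so far in an ADME assay on microsomes from liver (Mus musculus) for metabolic stability, read by LC-MS, using NADPH, with a stated time of 10 min, tested at 0.1 uM; a higher number here means faster removal of the compound, a lower number slower removal:
compound 1, `CC1SC(c2cccc(C(=O)NCCCCc3ccccc3)c2)N(c2ccc(C3CC3)cc2)C1=O`, 3210 mL.min-1.g-1
compound 2, `O=C(NCCCCc1ccccc1)c1cccc(C2SCC(=O)N2c2cccc(-c3c[nH]nn3)c2)c1`, 951 mL.min-1.g-1

Compound 1 stands at the higher of the two numbers; compound 2, its nearest neighbour, gives a number lower by a margin beyond the usual scatter. Among the compounds with values here, no step between two measured compounds that differ in a single place is available, so the read-across to the next compound rests on compound 1 alone. Compound 3, `COc1ccccc1N1C(=O)C(C)SC1c1cccc(C(=O)NCCCCc2ccccc2)c1`, differs from compound 1 in one place: 2-methoxyphenyl in place of 4-cyclopropylphenyl on an amide-type nitrogen in a ring. The group that leaves and the group that enters both carry no hydrogen-bond donor, the group that enters brings one hydrogen-bond acceptor, and the shared core of compound 1 is otherwise kept. Within the data shown here, with no measured step of this kind to lean on, the expected step of a 1.3-fold lower number from compound 1 to compound 3 (0.13 log units; within the scatter) is a modest downward one, not confidently beyond the scatter. Compound 3 is estimated at 2400 mL.min-1.g-1 in this assay, with a range from 1100 mL.min-1.g-1 to 5000 mL.min-1.g-1.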

Compound 3, intrinsic clearance in microsomes: 2950 mL.min-1.g-1
Compound 3: the middle estimate sits 1.2-fold (0.09 log units) below what was measured; low and high end bracket the measured number.
By their numbers in this assay, from the lowest: compound 2; then compounds 3 and 1 (each within the scatter of the next).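

In this assay, 2-methoxyphenyl in place of 4-cyclopropylphenyl on the amide-type nitrogen in the ring gives a 1.1-fold lower number from compound 1 to compound 3 (0.04 log units; within the scatter). This single-place step shows that, on this nitrogen, exchanging one of these two aryl groups for the other, with the three-membered ring gone and a hydrogen-bond acceptor added, leaves the read-out within the scatter. Nothing measured here speaks to the reason for this result.

From the compounds shown here alone, whether a phenyl group bearing an amine or a carboxylic acid at this place would move the number beyond the scatter stays open. Compound 2 differs from compound 1 in more than one place, so its lower number in this assay cannot be assigned to any single change.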